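A few compounds are considered here, and "the series" means these few. Any claim that something is new, unique, unknown or untested is made for them only; others in the source may bear on it.

In a functional assay on RT-112 cells (Homo sapiens) for antiproliferative activity, read by MTT assay, with a stated time of 72 h (on this read-out higher numbers stand for weaker inhibition of growth and lower numbers for stronger inhibition of growth), compound 1 `COc1cc(NC(=O)Nc2cccc3c(Nc4cc(OC)cc(OC)c4)ncnc23)cc(OC)c1` gives 366 nM and compound 3 `COc1cc(Nc2ncnc3c(NC(=O)Nc4ccc5c(c4)OCCO5)cccc23)cc(OC)c1` gives 2750 nM. These two compounds share a core and differ in one group on an amide-type nitrogen. Replacing 3,5-dimethoxyphenyl with 2,3-dihydro-1,4-benzodioxin-6-yl produces a 7.5-fold higher number from compound 1 to compound 3 (0.88 log units; beyond the scatter). Compound 3 therefore holds the higher of the two true numbers in this small set. Compound 2 `COc1cc(Nc2ncnc3c(NC(=O)Nc4ccc(C(F)(F)F)cc4[N+](=O)[O-])cccc23)cc(OC)c1` returned only a limit, > 20000 nM, and not a number.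

Compound 4 `COc1cc(Nc2ncnc3c(NC(=O)Nc4ccc(C(F)(F)F)cc4Cl)cccc23)cc(OC)c1` keeps the core of compound 3 and changes the same place: 2-chloro-4-(trifluoromethyl)phenyl stands in place of 2,3-dihydro-1,4-benzodioxin-6-yl on the amide-type nitrogen, (2-chloro-4-(trifluoromethyl)phenyl in place of 2,3-dihydro-1,4-benzodioxin-6-yl on an amide-type nitrogen). Two results bear on this change. The first is a 7.5-fold higher number from compound 1 to compound 3 (0.88 log units; beyond the scatter), which shows that a swap at this place can move the number well beyond the scatter. Among the measured compounds shown here, the second is compound 2, the only measured compound with a trifluoromethyl group on the ring at this place, which stands at its limit of > 20000 nM. With so little evidence, only a modest move towards weaker growth inhibition is expected, and the estimated change is a 2.2-fold higher number from compound 3 to compound 4 (0.34 log units; beyond the scatter). For compound 4 the expected value is 6000 nM, with an estimated range from 1500 nM to 20000 nM.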

Compound 4, concentration for 50% growth inhibition: 1080 nM
Compound 4: the middle estimate sits 5.6-fold (0.74 log units) above what was measured, outside the stated range (below it).
By their numbers in this assay, from the lowest: compound 1; then compound 4; then compound 3. At a limit, above all of these: compound 2.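

In this assay, a trifluoromethyl group on the ring at this place does not by itself rule out growth inhibition: 2-chloro-4-(trifluoromethyl)phenyl on the amide-type nitrogen gives a 2.5-fold lower number from compound 3 to compound 4 (0.41 log units; beyond the scatter), so this group does better than 2,3-dihydro-1,4-benzodioxin-6-yl, but it falls short of 3,5-dimethoxyphenyl, with a 3.0-fold higher number from compound 1 to compound 4 (0.47 log units; beyond the scatter). Among the compounds shown here, the largest contrast comes from one small swap on the same ring, chloro in place of nitro on an aromatic carbon, which gives an at least 18-fold lower number from compound 2 to compound 4 (1.26 log units; beyond the scatter), a step with only one true number behind it. Compound 2 is held at a limit and not at a number: the limit of > 20000 nM in this assay, at which 1 of the 4 values shown sits.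

On these data alone, how much chloro and trifluoromethyl each contribute on their own stays open, since the two appear here only together in compound 4. Also open, as far as these compounds go, is whether another group on this ring, such as an amine or a carboxylic acid, would match compound 1, at 366 nM.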